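Replacing the Benzothiazolyl Group with a Pyridinylmethoxy Group

The source may report more compounds than this note shows. Statements on the series, on what has been measured and on what is new or still open speak of the compounds shown alone.

Compound 1 `O=C(O)CCCSCCN1C(=O)CC[C@@H]1/C=C/[C@@H](O)Cc1cccc(-c2ccc3[nH]ccc3c2)c1`: in an assay on CHO cells for displacement of a labelled ligand from prostaglandin E2 receptor EP3 subtype (Mus musculus), read by scintillation counting, with a stated time of 60 min (on this read-out higher numbers stand for weaker inhibition and lower numbers for stronger inhibition), compound 1 gives > 10000 nM, which is a limit of the assay.
Compound 2 `O=C(O)CCCSCCN1C(=O)CC[C@@H]1/C=C/[C@@H](O)Cc1cccc(-c2nc3ccccc3s2)c1`: in this assay compound 2 gives > 10000 nM, which is a limit of the assay.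

Compound 2 thus sits at the same limit as the other measured compound, and the limit of > 10000 nM in this assay, at which 2 of the 2 values shown sit, is all that places it; no number sets it apart from compound 1. The step that the two limits leave unreadable from compound 1 to compound 2 runs between two limits and so has no readable size. Compound 3 `O=C(O)CCCSCCN1C(=O)CC[C@@H]1/C=C/[C@@H](O)Cc1cccc(OCc2ccncc2)c1` differs from compound 2 in one place: (pyridin-4-yl)methoxy in place of 1,3-benzothiazol-2-yl on an aromatic carbon. For the measured compounds named here, no measured step bears on this change, and the only step recorded gives no size at all. The expectation for compound 3 therefore rests on the two limits alone, which show only that neither the 1H-indol-5-yl nor the 1,3-benzothiazol-2-yl group produced a readable number in this assay. The step from compound 2 to compound 3 is expected to be an at least 1.2-fold lower number from compound 2 to compound 3 (0.09 log units; that floor lies within the scatter), with no direction the data can support. Compound 3 is estimated at 8000 nM, within a range from 500 nM to 50000 nM, and a further limit rather than a number is thought likely.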

Compound 3, inhibition constant: > 10000 nM
Compound 3: a limit, no number; the forecaster's own chance of this, stated with the estimate: 60%; middle value at least 1.2-fold (0.09 log units) from the limit.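

In this assay compound 3 gives > 10000 nM, which is a limit of the assay. The steps joining compound 3 to compound 1 and compound 2 therefore cannot be read, and the three compounds stand together: the limit of > 10000 nM in this assay, at which 3 of the 3 values shown sit.

The compounds shown leave open whether any group on this aromatic carbon would give a readable number in this assay.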